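The compounds below may be only part of what the source reports. "The series", "measured", "known", "first", "only" and "open" are said of these compounds alone.

The compounds here share one core, with a side arm joined to it through a nitrogen. Compound 2 `O=[N+]([O-])c1cccc(CNc2cc(C(F)(F)F)cc3[nH]ncc23)c1` is the starting point. For the measured compounds named here, in an assay for inhibition of Tryptophan 2,3-dioxygenase (Homo sapiens), with stated times of 10 min and 60 min, tested at 100 uM (a higher number here means a stronger effect of the compound at the concentration tested, a lower number a weaker effect), compound 2 gives 82%, the second highest of the three numbers known. Where compound 2 carries trifluoromethyl, compound 1 `O=[N+]([O-])c1cccc(CNc2cc(Br)cc3[nH]ncc23)c1` carries bromo, and in this assay compound 1 gives 97%; the step of a number 15 percentage points lower from compound 1 to compound 2 (beyond the scatter) is the only one-place change measured so far. Compound 3 `FC(F)(F)c1cc(NCc2cccc3sccc23)c2cn[nH]c2c1` has a different side arm altogether and gives 5% in this assay; compound 3 and compound 2 differ in more than one place, so their two values can only be set side by side.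

Going by the values given here, compound 4 `O=C(O)c1cccc(CNc2cc(C(F)(F)F)cc3[nH]ncc23)c1` has not yet been measured. carboxy in place of nitro on an aromatic carbon No measured step bears on this change: the one known step concerns the group on the core, and the gap between compound 2 and compound 3 comes from exchanging the whole side arm. The direction and size of the step in this assay are therefore open, and the expected step of a number 37 percentage points lower from compound 2 to compound 4 (beyond the scatter) is set near the middle of the range seen so far. For compound 4 the estimate is 45%, expected to fall between 5% and 85%.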

Compound 4, a percentage reported as inhibition, at one concentration (the size of the read-out at that concentration, not a potency): 94%
Compound 4: middle estimate off by 49 percentage points, on the low side, outside the stated range (above it).
By their numbers in this assay, from the lowest: compound 3; then compound 2; then compounds 4 and 1 (each within the scatter of the next).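

In this assay, for the compounds shown here, exchanging nitro for carboxy brings a number 12 percentage points higher from compound 2 to compound 4 (beyond the scatter), which is the first one-place change measured on the side arm rather than on the core. It shows that this aromatic carbon, meta to a large group, can carry a group other than nitro without losing the effect, even though the two groups differ in their hydrogen-bond counts: nitro has no hydrogen-bond donor, and carboxy has 1. Nothing measured on these compounds explains why the number rises with this change.

This single step cannot show whether the hydrogen-bond donor of carboxy matters, and a methyl ester or an amide at the same place would help to separate that from the exchange of the group as a whole. It also leaves open whether carboxy would give a similar step with bromo in place of trifluoromethyl on the core, and how the compounds would compare in potency, since each number is a read-out at a single concentration.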